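The source may report more compounds than this note shows. Statements on the series, on what has been measured and on what is new or still open speak of the compounds shown alone.

Of the compounds shown here, two have been measured in a functional assay on CHO cells with adenosine receptor A1 (Homo sapiens) as the target, read by cAMP accumulation and immunoassay, with a stated time of 6 min, tested at 10 uM; a lower number here means a stronger effect, a higher number a weaker effect of the compound at the concentration tested. Compound 1, with the structure `Nc1scc(CN2CCN(c3ccccc3C(F)(F)F)CC2)c1C(=O)c1ccc(Cl)cc1`, gives -60% in this assay, the lowest of the two numbers and therefore the stronger effect of the pair. Among the measured compounds shown here, compound 2, with the structure `Nc1scc(CN2CCN(c3c(F)cccc3F)CC2)c1C(=O)c1cccc(C(F)(F)F)c1`, gives 4% in this assay, a number well beyond the scatter away from compound 1; compound 2 differs from compound 1 in more than one place, so no single step can be drawn between them.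

Compound 3, with the structure `Nc1scc(CN2CCN(c3cccc(F)c3)CC2)c1C(=O)c1ccc(Cl)cc1`, has not yet been measured. It differs from compound 1 by one change: 3-fluorophenyl in place of 2-(trifluoromethyl)phenyl on an amine nitrogen in a ring. For the measured compounds named here, no measured pair in this set shows such a change on its own, so its size can only be guessed.

Going by the values given here, the step from compound 1 to compound 3 is expected to be a number 30 percentage points higher from compound 1 to compound 3 (beyond the scatter), toward a higher number, since the only comparison at hand, compound 2 at 4%, lies far above compound 1. Compound 3 is therefore estimated to give -30% in this assay, within a range from -65% to 10%.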

Compound 3, a percentage reported as activity, at one concentration (the size of the read-out at that concentration, not a potency): -82%
Compound 3: middle estimate off by 52 percentage points, on the high side; the measured number lies below the stated range.
By their numbers in this assay, from the lowest: compound 3; then compound 1; then compound 2.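

The change of 2-(trifluoromethyl)phenyl to 3-fluorophenyl on an amine nitrogen in a ring, with the rest of the core of compound 1 kept, gives in this assay a number 22 percentage points lower from compound 1 to compound 3 (beyond the scatter). Among the compounds shown here, this is the first comparison in the set that isolates one place, and it shows that this aromatic group can be changed without losing the effect: the entering group has fewer heavy atoms, and the effect at the tested concentration grows stronger. Nothing measured alongside these numbers accounts for the shift, so its cause remains unknown.

The step changes both the substituent and its location on the aromatic ring, so the compounds shown cannot separate what removing the trifluoromethyl group contributes from what adding the fluorine at its new place contributes. Also open, on these data alone, is how an unsubstituted phenyl ring, or one carrying a methoxy group, an amine or a carboxylic acid, would read at this same position on the core of compound 3.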